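Growth inhibition of a branched acid, estimated from one step

The source may hold more compounds than are shown below. What is called first, only, known or untested is meant among the compounds shown, and "the series" means these compounds.

Compound 1 (`C=C(CCCC)C(=O)c1ccc(OCC(=O)O)c(C)c1C`) gives 14400 nM
Compound 2 (`C=C(CCCC)C(=O)c1ccc(OCC(=O)OC)c(C)c1C`) gives 8600 nM

For the measured compounds named here, in a functional assay on HL-60 cells (Homo sapiens) for antiproliferative activity, with a stated time of 72 h (a lower number here means a stronger inhibitor of growth, a higher number a weaker inhibitor of growth), compound 2 stands within the scatter of compound 1, the only other compound measured. Compound 3 (`C=C(CCCC)C(=O)c1ccc(OC(C)C(=O)O)c(C)c1C`) differs from compound 2 by 1-carboxyethyl in place of (methoxycarbonyl)methyl on an oxygen on an aromatic ring. Going by the values given here, the one measured step that bears on this change is a 1.7-fold lower number from compound 1 to compound 2 (0.22 log units; within the scatter), which joins an acid to its methyl ester and stays within the scatter. Among the compounds with values here, no measured compound carries the 1-carboxyethyl group itself, so only a small move towards the value of the acid is expected. The expected change is a 1.4-fold higher number from compound 2 to compound 3 (0.14 log units; within the scatter), which would not go beyond the scatter. Compound 3 is estimated at 12000 nM, with an expected range of 6000 nM to 24000 nM.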

Compound 3, concentration for 50% growth inhibition: 12100 nM
Beside the measured number, compound 3's estimate is 1.0-fold (0.00 log units) below it, and the stated range covers the measured number.
By their numbers in this assay, from the lowest: compounds 2, 3 and 1 (each within the scatter of the next).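

In this assay, methyl in place of hydrogen on the saturated chain carbon bound to a carbonyl carbon and an oxygen on an aromatic ring gives a 1.2-fold lower number from compound 1 to compound 3 (0.08 log units; within the scatter) and so leaves the acid within the scatter. Likewise, 1-carboxyethyl in place of (methoxycarbonyl)methyl on that oxygen gives a 1.4-fold higher number from compound 2 to compound 3 (0.15 log units; within the scatter) and also stays within the scatter, so neither change separates these compounds at this position. No evidence is available on what lies behind these small steps. As far as these compounds go, whether an ethyl group or a longer chain on that carbon, or an amide in place of the acid, would go beyond the scatter remains open.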